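The compounds below may be only part of what the source reports. "The series", "measured", "known", "first", "only" and "open" are said of these compounds alone.

Measured so far:
Compound 1 `CCCN(CC1CC1)c1cc(SC)nc2c(-c3ccc(Cl)cc3Cl)c(C)nn12`: 0.73 nM
Compound 2 `CCCN(CCC)c1cc(C)nc2c(-c3ccc(C(=O)O)cc3)c(C)nn12`: > 10000 nM

Of the compounds shown here, two have been tested in an assay on isolated protein for binding affinity to corticotropin-releasing factor receptor 1 (Homo sapiens); on this read-out lower numbers stand for stronger inhibition and higher numbers for weaker inhibition. Within the data shown here, compound 1 gives 0.73 nM, the only actual number among the two results. Compound 2 gives only > 10000 nM, which is a limit of the assay and not a number. Among the measured compounds shown here, compound 1 therefore stands alone as the sole measured value, with the other result sitting at the limit of > 10000 nM in this assay, at which 1 of the 2 values shown sits. For the measured compounds named here, compound 1 and compound 2 differ in several places at once, so their pair gives no single step that can be read.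

Compound 3 `CCCN(CC1CC1)c1cc([S+](C)[O-])nc2c(-c3ccc(Cl)cc3Cl)c(C)nn12` has not yet been measured. It differs from compound 1 in one place: a group of 3 heavy atoms (1 carbon, 1 oxygen, 1 sulfur; no ring) in place of a group of 2 heavy atoms (1 carbon, 1 sulfur; no ring), on an aromatic carbon. Going by the values given here, no measured pair shows this kind of change, so the size of the step in this assay cannot be read from the data. For compound 3 the expectation is a modest loss, a step of a 6.8-fold higher number from compound 1 to compound 3 (0.84 log units; beyond the scatter) beyond the scatter but small. Compound 3 is estimated at 5 nM, with a range from 1 nM to 30 nM.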

Compound 3, inhibition constant: 8.6 nM
For compound 3 the middle estimate is 1.7-fold (0.24 log units) below the measured one, within the range that was stated.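

In this assay, among these compounds, replacing methylsulfanyl with the group that holds oxygen as well as carbon and sulfur, on the aromatic carbon next to the ring nitrogen, gives the first single change that can be read at this position: a 12-fold higher number from compound 1 to compound 3 (1.07 log units; beyond the scatter). The position is therefore sensitive to this change, with a step beyond the usual scatter, yet compound 3 still gives a measured number of 8.6 nM and not a limit of the assay. Nothing shown here speaks to the cause of this step.

Going by these compounds, with a single replacement at this carbon, it remains open how a methylsulfonyl group, a methoxy group or a primary amine in the same place would compare with methylsulfanyl. On these data alone, it is also open whether the same replacement would produce a step of similar size on a version of the core carrying a different amino group or a different aromatic ring in place of those of compound 1.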